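Anilino series: saturated ring in place of the aryl group

The compounds below may be only part of what the source reports. "The series", "measured", "known", "first", "only" and "open" are said of these compounds alone.

In a functional assay on ECa-109 cells for inhibition, with ECa-109 cell line (Homo sapiens) as the target, read by sulforhodamine B assay (a higher number here means a weaker inhibitor, a lower number a stronger inhibitor), compound 1 `O=C1C(Nc2cccc(Cl)c2)=CC(=O)c2c1nc1n2[C@H]2OC[C@@H](O)[C@H]2OC1` gives 3080 nM. Compound 2 `CCOc1ccccc1NC1=CC(=O)c2c(nc3n2[C@H]2OC[C@@H](O)[C@H]2OC3)C1=O` gives 4320 nM in this assay, so that a 1.4-fold higher number from compound 1 to compound 2 (0.15 log units; within the scatter). Compound 3 `Cc1ccc(NC2=CC(=O)c3c(nc4n3[C@H]3OC[C@@H](O)[C@H]3OC4)C2=O)cc1` reaches only a limit in this assay, > 4000 nM, not a number; this is the limit of > 4000 nM in this assay, at which 1 of the 3 values shown sits. Accordingly an at least 1.2-fold higher number from compound 1 to compound 3 (0.11 log units; that floor lies within the scatter), and a step that the limit leaves unreadable from compound 2 to compound 3. Compound 4 `O=C1C(NC2CCCCC2)=CC(=O)c2c1nc1n2[C@H]2OC[C@@H](O)[C@H]2OC1` differs from compound 3 by cyclohexyl in place of 4-methylphenyl on an amine nitrogen. For the measured compounds named here, every measured step here exchanges one aryl group for another; none replaces an aryl group with a saturated ring, so no measured step bears directly on this change and no direction is set by the data. The step is expected to be a step that the limit leaves unreadable from compound 3 to compound 4. Compound 4 is therefore estimated at 5000 nM in this assay, within 1800 nM to 15000 nM, with a fair chance that only a limit is returned again.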

Compound 4, half-maximal inhibitory concentration: > 16000 nM
Compound 4: only a limit was reported (the forecaster's own chance of this, stated with the estimate: 50%); middle value at least 3.2-fold (0.50 log units) away from the limit.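

Cyclohexyl is the first saturated ring on this amine nitrogen, and in this assay the aryl-to-aryl steps within the scatter give way to an at least 3.7-fold higher number from compound 2 to compound 4 (0.56 log units; beyond the scatter) and an at least 5.1-fold higher number from compound 1 to compound 4 (0.71 log units; beyond the scatter). Compound 4 reaches only a limit, not a number: the limit of > 16000 nM in this assay, at which 1 of the 4 values shown sits. Compound 3 is also a limit, and the steps that depend on it for size cannot be read: the limit of > 4000 nM in this assay, at which 1 of the 4 values shown sits.

On these data alone, whether the saturated ring itself or the loss of the aryl group matters stays open. A cyclopentyl or benzyl group on this amine nitrogen would help separate the two.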